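Removing a trifluoromethyl from a benzamide: an expected step

This account rests on a few compounds, and the source may have more. Where it says the series, first, only, none or still open, it means among the compounds named here.

Measured compounds:
- compound 1, `COc1cc(-c2nn(-c3cccc(NC(=O)c4cccc(C(F)(F)F)c4)c3)cc2-c2ccncc2)ccc1Cl`, 17600 nM
- compound 2, `O=C(Nc1cccc(-n2cc(-c3ccncc3)c(-c3ccc(Cl)c(O)c3)n2)c1)Nc1cc(C(F)(F)F)cc(C(F)(F)F)c1`, 2410 nM

The two compounds were tested in a functional assay on HCC 2998 cells (Homo sapiens) for inhibition, read by sulforhodamine B assay, with a stated time of 48 h; on this read-out higher numbers stand for weaker inhibition of growth and lower numbers for stronger inhibition of growth. Of the two numbers, compound 1 has the higher one at 17600 nM, and compound 2 sits at 2410 nM, a gap that lies beyond the usual scatter. The two compounds differ in more than one place, so nothing is said here about why.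

Compound 3, `COc1cc(-c2nn(-c3cccc(NC(=O)c4ccccc4)c3)cc2-c2ccncc2)ccc1Cl`, is not yet measured. It differs from compound 1 in one spot: hydrogen in place of trifluoromethyl on an aromatic carbon. In words, hydrogen takes the place of trifluoromethyl on an aromatic carbon, so the 3-(trifluoromethyl)phenyl becomes a plain phenyl, and the (3-(trifluoromethyl)phenyl)carbonyl becomes a benzoyl.

For the measured compounds named here, no pair of measured compounds shows this change, so there is no directly comparable step. Given only that compound 1 already holds the weaker number at 17600 nM, the expectation is a modest move toward weaker growth inhibition, roughly at the edge of the scatter, as a 1.7-fold higher number from compound 1 to compound 3 (0.23 log units; within the scatter). For compound 3 the estimate is 30000 nM, with a range from 10000 nM to 80000 nM.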

Compound 3, concentration for total growth inhibition: 22400 nM
The estimate for compound 3 lay 1.3-fold (0.13 log units) above the measured number, within the range that was stated.
By their numbers in this assay, from the lowest: compound 2; then compounds 1 and 3 (each within the scatter of the next).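

In this assay, replacing trifluoromethyl with hydrogen, which turns the 3-(trifluoromethyl)phenyl into a plain phenyl and the (3-(trifluoromethyl)phenyl)carbonyl into a benzoyl, gives a 1.3-fold higher number from compound 1 to compound 3 (0.10 log units; within the scatter). For the compounds shown here, this is the first comparison here in which only one place differs, and it shows that at this position, on an aromatic carbon meta to a large group, the core of compound 1 can lose the 4 heavy atoms of trifluoromethyl with no shift in the number beyond the usual scatter, so this group is not required to keep growth inhibition at the level of compound 1. Nothing available here bears on why the two numbers lie so close together.

Whether an amine or a carboxylic acid on that same aromatic carbon would also leave the number within the scatter remains open, since hydrogen is the only replacement shown. The steps from compound 2 to compound 1 and to compound 3 cannot be read, as compound 2 differs from each in more than one place, so what lies behind its lower number also stays open.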